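The source may hold more compounds than are shown below. What is called first, only, known or untested is meant among the compounds shown, and "the series" means these compounds.

Measured so far in a functional assay on MDA-MB-231 cells (Homo sapiens) for cytotoxicity, read by sulforhodamine B assay, with a stated time of 48 h; on this read-out higher numbers stand for weaker inhibition of growth and lower numbers for stronger inhibition of growth:

compound 1, `COc1ccc(-c2ccc(C)n2-c2ccc(-c3nc4ccc(F)cc4s3)cc2)cc1`: 3070 nM
compound 2, `COc1ccc(-c2ccc(C)n2-c2ccc(-c3nc4ccc(OC)cc4s3)cc2)cc1`: 4120 nM
compound 3, `COc1cc2nc(-c3ccc(-n4c(C)ccc4-c4ccc(F)cc4)cc3)sc2c(OC)c1OC`: 3940 nM

The three numbers sit close together; none of the gaps between them is printed as beyond the scatter, so no order among compound 1, compound 2 and compound 3 is read from them.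

For the measured compounds named here, the one single-point change measured so far is methoxy in place of fluoro on an aromatic carbon, which gave a 1.3-fold higher number from compound 1 to compound 2 (0.13 log units; within the scatter) in this assay. How the core of compound 3 differs from the core of compound 1 is not broken down here.

Compound 4, `COc1ccc(-c2ccc(C)n2-c2ccc(-c3nc4cc(OC)c(OC)c(OC)c4s3)cc2)cc1`, is not yet measured. It stands to compound 3 as compound 2 stands to compound 1: methoxy in place of fluoro on an aromatic carbon. The surroundings are not the same, however. In the earlier case the carbon belongs to a ring that is part of a fused system, meta to a fused ring and para to a fused ring; here it belongs to a six-membered aromatic ring of carbon only, para to a large group. It is therefore the same kind of change, not the same change.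

In this assay the expected step is a 1.2-fold higher number from compound 3 to compound 4 (0.09 log units; within the scatter), set beside a 1.3-fold higher number from compound 1 to compound 2 (0.13 log units; within the scatter), on which it rests. Compound 4 is thus estimated at 4800 nM, with a range from 2400 nM to 9600 nM.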

Compound 4, concentration for 50% growth inhibition: 2240 nM
The estimate for compound 4 lay 2.1-fold (0.33 log units) above the measured number, and the stated range ends above it.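

In this assay, methoxy in place of fluoro on the core of compound 3, read as 4-fluorophenyl to 4-methoxyphenyl, gave a 1.8-fold lower number from compound 3 to compound 4 (0.25 log units; within the scatter), so this step stays within the usual scatter of repeated measurements. Set beside the earlier step on the other core, the new step does not show that the core changes the outcome of this swap:  the same change on two cores in this assay, a 1.3-fold higher number (0.13 log units; within the scatter) from compound 1 to compound 2 and a 1.8-fold lower number (0.25 log units; within the scatter) from compound 3 to compound 4, 2.4-fold (0.37 log units) apart, within the scatter of two such steps

For the compounds shown here, with only two pairs, both within the scatter, the series shows no effect of this swap that could be carried from one core to another, and it neither proves that the swap is equally small on every core nor gives it a direction.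

Open, going by these compounds, is whether a group other than fluoro and methoxy in this place, such as an amine, a carboxylic acid or a longer chain, would move the number beyond the scatter. Also open, on these data alone, is whether such a step would keep its size when carried between the core of compound 1 and the core of compound 3.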